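This account rests on a few compounds, and the source may have more. Where it says the series, first, only, none or still open, it means among the compounds named here.

Measured compounds: compound 1 `CN1CC=C(c2cn(C(=O)c3ccccc3)c3ccccc23)CC1`, compound 2 `Nc1ccc(S(=O)(=O)n2cc(C3=CCNCC3)c3cc([N+](=O)[O-])ccc32)cc1`, compound 3 `O=S(=O)(c1ccccc1Cl)n1cc(C2=CCNCC2)c2ccccc21`.

In an assay on HeLa cells for binding affinity to 5-hydroxytryptamine receptor 6 (Homo sapiens) (on this read-out higher numbers stand for weaker inhibition and lower numbers for stronger inhibition), compound 3 gives 0.4 nM, the lowest number of the three. Compound 2 gives 29 nM and compound 1 gives 99 nM; both gaps to compound 3 lie beyond the usual scatter, so compound 3 is the strongest binder of the measured set.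

Compound 4 `COc1ccc(S(=O)(=O)n2cc(C3=CCNCC3)c3ccccc32)cc1` differs from compound 3 by one change: 4-methoxyphenyl in place of 2-chlorophenyl on a sulfonyl sulfur. Going by the values given here, no step between measured compounds covers this change, so its size is unknown from the data. A modest weakening, somewhat beyond the scatter, is expected for the step of a 7.5-fold higher number from compound 3 to compound 4 (0.88 log units; beyond the scatter) in this assay. Compound 4 is therefore estimated at 3 nM, within a range from 0.5 nM to 20 nM.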

Compound 4, inhibition constant: 18 nM
For compound 4 the middle estimate is 6.0-fold (0.78 log units) below the measured one; the range from low to high includes it.
By their numbers in this assay, from the lowest: compound 3; then compounds 4 and 2 (each within the scatter of the next); then compound 1.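

Swapping the group on the sulfonyl sulfur has a large effect: 4-methoxyphenyl in place of 2-chlorophenyl gives a 45-fold higher number from compound 3 to compound 4 (1.65 log units; beyond the scatter), the first measured step at this position, and it shows that binding here depends strongly on this group. No measurement at hand explains the size of this step.

The change replaces both the substituent and its place on the phenyl ring, so the compounds shown do not separate the two; 4-chlorophenyl or 2-methoxyphenyl would. As far as these compounds go, whether a pyridine ring on the sulfonyl sulfur would keep the binding of compound 3 also remains open.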